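A few compounds are considered here, and "the series" means these few. Any claim that something is new, unique, unknown or untested is made for them only; others in the source may bear on it.

Measured so far:
compound 1 `Cc1cc(NC(=O)Cn2nnc(-c3ccccc3)n2)n(C2CCCCC2)n1`, 92%
compound 2 `COc1ccc(-c2nnn(CC(=O)Nc3cc(C)nn3C3CCCCC3)n2)cc1`, 90%

In an assay on HEK293 cells for activation of Kir3.1/Kir3.2 (Homo sapiens), read by thallium flux (on this read-out lower numbers stand for smaller maximal responses and higher numbers for larger maximal responses), compound 1 gives 92%. In this assay compound 2 gives 90%, the lowest of the two numbers; its nearest neighbour is compound 1, a number 2 percentage points lower from compound 1 to compound 2 (within the scatter), so the two sit within the scatter of each other. The next compound, compound 3 `Cc1cc(NC(=O)Cn2nnc(-c3cccc(C(F)(F)F)c3)n2)n(C2CCCCC2)n1`, is not yet measured. It differs from compound 2 by 3-(trifluoromethyl)phenyl in place of 4-methoxyphenyl on an aromatic carbon. Among the compounds with values here, the one step on record, a number 2 percentage points lower from compound 1 to compound 2 (within the scatter), also alters the group on the same aromatic carbon and stayed within the scatter, which is the only guide; no measured step covers a trifluoromethyl group. On that basis the largest response of compound 3 is expected to remain close to that of compound 2, no change at the digits printed from compound 2 to compound 3 (within the scatter), with no step beyond the scatter. Compound 3 is therefore estimated at 90% in this assay, within 76% to 102%.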

Compound 3, largest response reached (Emax), in percent of the reference or control that the assay uses: 86%
Compound 3: middle estimate off by 4 percentage points, on the high side; the range from low to high includes it.
By their numbers in this assay, from the lowest: compounds 3, 2 and 1 (each within the scatter of the next).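

In this assay, the position on the aromatic carbon of the five-membered aromatic ring with 4 nitrogen accepts 3-(trifluoromethyl)phenyl in place of 4-methoxyphenyl with a number 4 percentage points lower from compound 2 to compound 3 (within the scatter). Trifluoromethyl in place of hydrogen on the phenyl ring gives a number 6 percentage points lower from compound 1 to compound 3 (within the scatter), so a fluorinated group and an entering group with 0 hydrogen-bond acceptors both stay within the scatter here, as the methoxy group did. No measurement on hand bears on the reason for these small differences.

Going by these compounds, whether an amine or a carboxylic acid on this phenyl ring would produce a step beyond the scatter remains open. Also open, on these data alone, is whether a longer alkyl chain in place of the whole aromatic group, or any change elsewhere on the shared core, would hold the maximal response.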